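The source may report more compounds than this note shows. Statements on the series, on what has been measured and on what is new or still open speak of the compounds shown alone.

Measured in an ADME assay on the whole organism (plasma, strain CD1) for pharmacokinetics, with Mus musculus as the target, at a dose of 200 mg/kg by the oral route; on this read-out lower numbers stand for lower exposure and higher numbers for higher exposure at the dose given:
- compound 1 `CCOC(=O)c1c(-c2cccc(-c3ccccc3)c2)[nH]c2cc(OC)ccc2c1=O`: 1720 ng.h/mL
- compound 2 `CCOC(=O)c1c(-c2cccc(OC)c2)[nH]c2cc(OC)ccc2c1=O`: 2760 ng.h/mL
- compound 3 `CCCOc1cccc(-c2[nH]c3cc(OC)ccc3c(=O)c2C(=O)OCC)c1`: 2940 ng.h/mL

Compound 3 stands at 2940 ng.h/mL in this assay, and neither of its steps to the other two compounds leaves the scatter. Compound 4 `CCOC(=O)c1c(-c2cccc(Oc3ccccc3)c2)[nH]c2cc(OC)ccc2c1=O` differs from it by phenyl in place of propyl on an oxygen on an aromatic ring, with phenyl in place of propyl on an oxygen on an aromatic ring.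

Going by the values given here, no measured compound carries this phenoxy group, so the evidence is indirect. Replacing phenyl with propoxy gave a 1.7-fold higher number from compound 1 to compound 3 (0.23 log units; within the scatter). Replacing phenyl with methoxy gave a 1.6-fold higher number from compound 1 to compound 2 (0.21 log units; within the scatter). Lengthening methoxy to propoxy gave a 1.1-fold higher number from compound 2 to compound 3 (0.03 log units; within the scatter). Among the compounds with values here, all three steps are small, so no step beyond the scatter is expected here, though the one measured compound with a phenyl group, compound 1 at 1720 ng.h/mL, suggests a slight lean toward a lower number. The expected change is a 1.3-fold lower number from compound 3 to compound 4 (0.11 log units; within the scatter). For compound 4 the estimate is 2300 ng.h/mL, with an expected range of 1200 ng.h/mL to 4300 ng.h/mL.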

Compound 4, area under the concentration-time curve: 415 ng.h/mL
The estimate for compound 4 lay 5.5-fold (0.74 log units) above the measured number, and the stated range ends above it.
By their numbers in this assay, from the lowest: compound 4; then compounds 1, 2 and 3 (each within the scatter of the next).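

In this assay, going by these compounds alone, the replacement of phenyl for propyl on an oxygen on an aromatic ring gives a 7.1-fold lower number from compound 3 to compound 4 (0.85 log units; beyond the scatter) and the replacement of phenyl for methyl on that oxygen gives a 6.7-fold lower number from compound 2 to compound 4 (0.82 log units; beyond the scatter); these are the first steps at this place to leave the scatter, since compounds 1, 2 and 3 all lie within it of one another. The oxygen also matters to the outcome, as exchanging the phenyl group for a phenoxy group gives a 4.1-fold lower number from compound 1 to compound 4 (0.62 log units; beyond the scatter), so the same ring behaves differently when attached through oxygen. Nothing available explains this drop.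

The compounds shown leave open whether the drop belongs to phenyl alone or to any ring on this oxygen, which a benzyl group, a cyclohexyl ring or a pyridine ring there would test. They also leave open whether an alkyl chain longer than propyl on the same oxygen stays level with compound 3.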